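This account rests on a few compounds, and the source may have more. Where it says the series, first, only, none or still open, it means among the compounds named here.

Compound 1 `O=C(Nc1ccc(I)cc1)N[C@H]1CC[C@H](Oc2ccc(F)cc2)CC1`: in a functional assay on CRL2813 cells (Homo sapiens) for cytotoxicity, read by sulforhodamine B assay, with a stated time of 5 days (a lower number here means a stronger inhibitor, a higher number a weaker inhibitor), compound 1 gives 10200 nM.
Compound 2 `Cc1ccc(NC(=O)N[C@H]2CC[C@H](Oc3ccc(F)cc3)CC2)cc1`: in this assay compound 2 gives > 20000 nM, which is a limit of the assay and not a number.
Compound 3 `O=C(Nc1cccc(F)c1)N[C@H]1CC[C@H](Oc2ccc(F)cc2)CC1`: in this assay compound 3 gives 8300 nM.

Among the compounds with values here, compound 3 has the lowest of the two actual numbers, but its only neighbour with a number is close: the step is a 1.2-fold lower number from compound 1 to compound 3 (0.09 log units; within the scatter), which lies within the scatter, so the two cannot be told apart. The third value is a limit: the limit of > 20000 nM in this assay, at which 1 of the 3 values shown sits.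

Compound 4 `CSc1ccccc1NC(=O)N[C@H]1CC[C@H](Oc2ccc(F)cc2)CC1` differs from compound 3 in one place: 2-(methylsulfanyl)phenyl in place of 3-fluorophenyl on an amide-type nitrogen. Within the data shown here, no measured step swaps in a methylsulfanyl group, so the expectation rests on the swaps of the ring on the same amide-type nitrogen that were measured. Those are an at least 2.4-fold lower number from compound 2 to compound 3 (0.38 log units; beyond the scatter), a 1.2-fold lower number from compound 1 to compound 3 (0.09 log units; within the scatter) and an at least 1.9-fold higher number from compound 1 to compound 2 (0.29 log units; that floor lies within the scatter). They show that changing this ring moved the number only modestly, and in one case not beyond the scatter.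

The step of a 1.2-fold higher number from compound 3 to compound 4 (0.08 log units; within the scatter) is therefore expected to be small, with the direction uncertain. Compound 4 is estimated at 10000 nM in this assay, with a likely range from 3000 nM to 30000 nM.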

Compound 4, half-maximal inhibitory concentration: > 20000 nM
Compound 4 was reported as a limit; the forecaster's own chance of this, stated with the estimate: 25%; middle value at least 2.0-fold (0.30 log units) away from the limit.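

Swapping in 2-(methylsulfanyl)phenyl on the amide-type nitrogen gives an at least 2.4-fold higher number from compound 3 to compound 4 (0.38 log units; beyond the scatter), so compound 3 now stands clearly apart from two of its ring variants rather than one. The same swap gives an at least 1.9-fold higher number from compound 1 to compound 4 (0.29 log units; that floor lies within the scatter), a floor that does not yet separate that pair, although among these four compounds the two rings carrying a halogen, in compound 1 and compound 3, give actual numbers, and the two without one, in compound 2 and compound 4, do not, with no compound here going against that split. The step between compound 2 and compound 4 cannot be read, and each of the two compounds stops at a limit and not a number: the limit of > 20000 nM in this assay, at which 2 of the 4 values shown sit.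

How far compound 2 and compound 4 really lie past that limit stays open, as does whether the split above truly follows the halogen, given that only four rings are shown. A ring bearing a chlorine, an amine or a carboxylic acid would test that split, and an ethylsulfanyl or methoxy group in place of methylsulfanyl would show whether the sulfur group itself matters.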